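This account rests on a few compounds, and the source may have more. Where it says the series, first, only, none or still open, it means among the compounds named here.

Measured in an assay on isolated protein for inhibition of Leucine-rich repeat serine/threonine-protein kinase 2 (Homo sapiens), read by TR-FRET and LanthaScreen, with stated times of 50 min and 30 min, in the presence of a further agent that is not named here; a lower number here means a stronger inhibitor, a higher number a weaker inhibitor:

- compound 1 `Cc1nn(CC2(O)COC2)cc1Nc1nc(N)c2c(C#N)c(N3CCC[C@H]3C)n(C)c2n1`: 57 nM
- compound 2 `C[C@@H]1CCCN1c1c(C#N)c2c(N)nc(Nc3ccn(C)n3)cc2n1C`: 234 nM
- compound 3 `Cn1c(N2CCCC2)c(C#N)c2c(N)ncnc21`: 1480 nM

Compound 1 gives the lowest number of the three and is the strongest inhibitor in this assay. The nearest is compound 2, whose higher number lies beyond the usual scatter; compound 3 is furthest, with a number well beyond the scatter above both. Going by the values given here, compound 2 and compound 3 differ from compound 1 in more than one place, so no single step between measured compounds is available.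

Compound 4 `Cc1nn(C2COC2)cc1Nc1nc(N)c2c(C#N)c(N3CCC[C@H]3C)n(C)c2n1` is not yet measured. It differs from compound 1 in one place: oxetan-3-yl in place of (3-hydroxyoxetan-3-yl)methyl on an aromatic nitrogen. The group that leaves carries one hydrogen-bond donor and two hydrogen-bond acceptors; the group that enters carries no hydrogen-bond donor and one hydrogen-bond acceptor, and has two fewer heavy atoms.

Among the compounds with values here, no measured pair shows what this change does in this assay. A modest step toward a higher number, of about the size of the usual scatter, is expected from compound 1 to compound 4, that is a 1.9-fold higher number from compound 1 to compound 4 (0.29 log units; within the scatter). Compound 4 is therefore estimated at 110 nM in this assay, with a range from 35 nM to 350 nM.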

Compound 4, half-maximal inhibitory concentration: 38 nM
Beside the measured number, compound 4's estimate is 2.9-fold (0.46 log units) above it; measured number inside the range.
By their numbers in this assay, from the lowest: compounds 4 and 1 (each within the scatter of the next); then compound 2; then compound 3.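

In this assay, oxetan-3-yl in place of (3-hydroxyoxetan-3-yl)methyl on the aromatic nitrogen gives a 1.5-fold lower number from compound 1 to compound 4 (0.18 log units; within the scatter), so this read-out does not separate the two compounds. For this pair, the group on that nitrogen can lose its hydrogen-bond donor, one hydrogen-bond acceptor and two heavy atoms, while the oxetane ring stays in place, without a step beyond the scatter. No measurement shown here bears on why the step is this small.

This single pair does not show whether the nitrogen accepts groups without an oxetane ring, such as a methyl, a piperidin-4-yl ring or a longer chain ending in a carboxylic acid, with an equally small step. It also leaves open whether the hydroxyl or the extra methylene of (3-hydroxyoxetan-3-yl)methyl matters on its own, which 3-hydroxyoxetan-3-yl or oxetan-3-ylmethyl on the same nitrogen of the core of compound 1 could separate.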